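The source may hold more compounds than are shown below. What is called first, only, known or untested is meant among the compounds shown, and "the series" means these compounds.

Series measured in a functional assay on BGC-823 cells (Homo sapiens) for antiproliferative activity, read by MTT assay, with a stated time of 24 h; a lower number here means a stronger inhibitor, a higher number a weaker inhibitor:
- Compound 1 `O=[N+]([O-])c1cccc(CSc2nnc(-c3ccc4c(c3)OCCO4)n2-c2ccccc2)c1`: 30100 nM
- Compound 2 `Clc1cccc(CSc2nnc(-c3ccc4c(c3)OCCO4)n2-c2ccccc2)c1`: 51200 nM
- Compound 3 `Fc1ccc(CSc2nnc(-c3ccc4c(c3)OCCO4)n2-c2ccccc2)cc1`: > 100000 nM

Compound 3 stands at the limit of > 100000 nM in this assay, at which 1 of the 3 values shown sits. It is a limit and not a number.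

Compound 4 `Fc1cccc(F)c1CSc1nnc(-c2ccc3c(c2)OCCO3)n1-c1ccccc1` carries 2,6-difluorophenyl in place of 4-fluorophenyl on a saturated chain carbon bound to a sulfur.

The nearest measured changes at this place are an at least 3.3-fold higher number from compound 1 to compound 3 (0.52 log units; beyond the scatter) and an at least 1.9-fold higher number from compound 2 to compound 3 (0.29 log units; that floor lies within the scatter). Both end on the limit, and neither goes from one fluorinated group to another. Only a small step is therefore expected, slightly towards a lower number, and its direction is uncertain. The expected step is an at least 1.2-fold lower number from compound 3 to compound 4 (0.09 log units; that floor lies within the scatter). For compound 4 the estimate is 80000 nM, with an expected range of 30000 nM to 200000 nM.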

Compound 4, half-maximal inhibitory concentration: 84200 nM
Estimate against measurement, compound 4: 1.1-fold (0.02 log units) below; measured number inside the range.
By their numbers in this assay, from the lowest: compounds 1, 2 and 4 (each within the scatter of the next, the first and the last beyond it). At a limit, above all of these: compound 3.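

Compound 4 gives a true number for a fluorinated group on a saturated chain carbon bound to a sulfur. Compound 3 remains a limit and not a number: the limit of > 100000 nM in this assay, at which 1 of the 4 values shown sits. In this assay, among these compounds, the change to 2,6-difluorophenyl reads as an at least 1.1-fold lower number from compound 3 to compound 4 (0.07 log units; that floor lies within the scatter) and as a 1.6-fold higher number from compound 2 to compound 4 (0.22 log units; within the scatter) so neither comparison separates the groups, whereas 3-nitrophenyl stands apart with a 2.8-fold higher number from compound 1 to compound 4 (0.45 log units; beyond the scatter) as the only step beyond the scatter.

Going by these compounds, how far the true gap between compound 3 and compound 4 exceeds its floor stays open. Also open, on these data alone, is how an amine, a carboxylic acid or a longer chain would read at this place.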